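The compounds below may be only part of what the source reports. "The series", "measured", "known", "first", "only" and "open" are said of these compounds alone.

Series notes. The shared core of compound 1 `COc1ccccc1C(=O)NC(=O)Nc1ccc(-c2ccccc2)c(C(C)C)c1` carries an imide linker to a substituted aromatic ring; the compounds differ in the two groups on that ring. In an in vitro ADME assay on microsomes from liver (Rattus norvegicus) for metabolic stability, with a stated time of 30 min (a lower number here means slower removal, a higher number faster removal of the compound), compound 1 gives < 14 mL.min-1.g-1, which is a limit of the assay and not a number. Compound 2 `COc1ccccc1C(=O)NC(=O)Nc1ccc(-c2nccs2)c(C(F)(F)F)c1` gives 33 mL.min-1.g-1. Compound 3 `COc1ccccc1C(=O)NC(=O)Nc1ccc(OCC(F)(F)F)c(C(F)(F)F)c1` gives 25 mL.min-1.g-1, the lowest of the two numbers available, with compound 2 nearest; the step from compound 2 to compound 3 is a 1.3-fold lower number from compound 2 to compound 3 (0.12 log units; within the scatter), so the two are indistinguishable here. The limit of < 14 mL.min-1.g-1 in this assay, at which 1 of the 3 values shown sits, adds no number to compare against.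

Compound 4 `COc1ccccc1C(=O)NC(=O)Nc1ccc(-c2ccccn2)c(C(F)(F)F)c1` is not yet measured. Its change from compound 3 is pyridin-2-yl in place of 2,2,2-trifluoroethoxy on an aromatic carbon. Going by the values given here, the only measured step that bears on this position is the one from compound 2 to compound 3, which exchanged a five-membered aromatic heterocycle for the trifluoroethoxy group and stayed within the scatter. Compound 4 reverses that kind of exchange, bringing back a small aromatic heterocycle with one hetero atom, so no step beyond the scatter is expected in this assay. Compound 4 is therefore estimated at 30 mL.min-1.g-1 (range 15 mL.min-1.g-1 to 60 mL.min-1.g-1), which means an expected step of a 1.2-fold higher number from compound 3 to compound 4 (0.08 log units; within the scatter) from compound 3.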

Compound 4, intrinsic clearance in microsomes: 15 mL.min-1.g-1
For compound 4 the middle estimate is 2.0-fold (0.30 log units) above the measured one; measured number inside the range.
By their numbers in this assay, from the lowest: compounds 4, 3 and 2 (each within the scatter of the next, the first and the last beyond it). At a limit, below all of these: compound 1.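

In this assay, going by these compounds alone, the position ortho to a trifluoromethyl group now gives a step beyond the scatter for the first time, with pyridin-2-yl in place of 1,3-thiazol-2-yl: a 2.2-fold lower number from compound 2 to compound 4 (0.34 log units; beyond the scatter). The two aromatic heterocycles therefore do not read alike here, so the presence of an aromatic ring with a hetero atom at this position does not by itself fix the number. The exchange of 2,2,2-trifluoroethoxy for pyridin-2-yl gives a 1.7-fold lower number from compound 3 to compound 4 (0.22 log units; within the scatter), which leaves compound 3 within the scatter of both neighbours, so that only compound 2 and compound 4 stand apart among the three numbers.

The data shown give no measured property that accounts for the difference between pyridin-2-yl and 1,3-thiazol-2-yl in this assay. Still open, on these data alone, is how a saturated amine such as morpholine or a carboxylic acid would read at this position, and how the number responds when the trifluoromethyl group is exchanged while pyridin-2-yl stays in place.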